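Thiophenyl for iodo on the methylamino core

A few compounds are considered here, and "the series" means these few. Any claim that something is new, unique, unknown or untested is made for them only; others in the source may bear on it.

Measured compounds:
compound 1 `COc1ncnc2c1c(-c1cccs1)cn2[C@@H]1O[C@H](CO)[C@@H](O)[C@H]1O` — 70 nM
compound 2 `Cc1ncnc2c1c(-c1cccs1)cn2[C@@H]1O[C@H](CO)[C@@H](O)[C@H]1O` — > 20000 nM
compound 3 `CNc1ncnc2c1c(I)cn2[C@@H]1O[C@H](CO)[C@@H](O)[C@H]1O` — > 100000 nM

In a functional assay on K562 cells (Homo sapiens), read by MTT assay, with a stated time of 72 h (a higher number here means a weaker inhibitor, a lower number a stronger inhibitor), compound 1 gives 70 nM. Compound 2 reaches only a limit of the assay, > 20000 nM. Compound 3 likewise gives only a limit, > 100000 nM, which is the limit of > 100000 nM in this assay, at which 1 of the 3 values shown sits; of the three values shown it is the one sitting at that limit, so compound 3 stands at the weak end of what is shown, with no number of its own.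

The step to compound 4 `CNc1ncnc2c1c(-c1cccs1)cn2[C@@H]1O[C@H](CO)[C@@H](O)[C@H]1O` is thiophen-2-yl in place of iodo on an aromatic carbon. Within the data shown here, no measured step covers this change directly. Among the measured compounds shown here, the one measured step, an at least 280-fold higher number from compound 1 to compound 2 (2.45 log units; beyond the scatter), concerns the substituent on the six-membered ring and not the place changed here. What bears on compound 4 is that compound 1 carries the same thiophen-2-yl group and gives 70 nM. Compound 3, with iodo, gives only a limit in this assay. A step in the direction of stronger inhibition is therefore expected, though its size is uncertain because compound 3 provides no number; the estimated step is an at least 100-fold lower number from compound 3 to compound 4 (2.00 log units; beyond the scatter). Compound 4 is expected to give 1000 nM, within 100 nM to 20000 nM.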

Compound 4, half-maximal inhibitory concentration: > 20000 nM
Compound 4: no number, only a limit; the forecaster's own chance of this, stated with the estimate: 25%; middle value at least 20-fold (1.30 log units) away from the limit.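

In this assay compound 4 reaches only a limit (> 20000 nM) and gives no number. Thiophen-2-yl on this aromatic carbon is therefore not sufficient on its own: methylamino in place of methoxy gives an at least 280-fold higher number from compound 1 to compound 4 (2.45 log units; beyond the scatter) on an otherwise shared core, and among the thiophen-2-yl compounds only compound 1 gives a number. The steps to compound 4 from compound 3 and from compound 2 have limits at both ends and cannot be read.

From the compounds shown here alone, whether thiophen-2-yl offers any gain over iodo stays open, as the methylamino pair gives limits on both sides. Also open, going by these compounds, is whether the activity seen with methoxy extends to ethoxy or a primary amine at that place, or survives a change from thiophen-2-yl to furan-2-yl on the aromatic carbon.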